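The source may hold more compounds than are shown below. What is called first, only, known or untested is meant among the compounds shown, and "the series" means these compounds.

In a functional assay on HCT-116 cells (Homo sapiens) for antiproliferative activity (a lower number here means a stronger inhibitor, a higher number a weaker inhibitor), three compounds sharing one core have been measured. Compound 1 `CC[C@H](N)C(=O)N1CCc2c(C)c3c(n2-c2ccc(C(N)=O)c(c2)N[C@@H](C)[C@H](C)C1)CC(C)(C)CC3=O` gives 33 nM, compound 2 `Cc1c2c(n3c1CCN(C(=O)[C@@H](N)C(C)C)C[C@@H](C)[C@H](C)Nc1cc-3ccc1C(N)=O)CC(C)(C)CC2=O` gives 30 nM and compound 3 `Cc1c2c(n3c1CCN(C(=O)[C@H](C)O)C[C@@H](C)[C@H](C)Nc1cc-3ccc1C(N)=O)CC(C)(C)CC2=O` gives 42 nM, so compound 3 sits level with the other two within the scatter of repeated measurements.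

Compound 4 `Cc1c2c(n3c1CCN(C(=O)[C@@H](O)C(C)C)C[C@@H](C)[C@H](C)Nc1cc-3ccc1C(N)=O)CC(C)(C)CC2=O` differs from compound 3 in one group: isopropyl in place of methyl on a saturated chain carbon bound to a carbonyl carbon and an oxygen on a saturated carbon. In other words, 1-hydroxyethyl becomes 1-hydroxy-2-methylpropyl.

The nearest guide is a 1.1-fold lower number from compound 1 to compound 2 (0.04 log units; within the scatter), where methyl in place of hydrogen enlarges the amino-bearing chain and the change stays within the scatter. Replacing those amino-bearing chains with 1-hydroxyethyl also stays within the scatter, as a 1.3-fold higher number from compound 1 to compound 3 (0.10 log units; within the scatter) and a 1.4-fold higher number from compound 2 to compound 3 (0.15 log units; within the scatter) show. Among the measured compounds shown here, no measured pair shows this enlargement on a hydroxy-bearing chain, so the guide is indirect.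

No step beyond the scatter is therefore expected in this assay, and neither direction is favoured. The estimated step is a 1.1-fold lower number from compound 3 to compound 4 (0.04 log units; within the scatter). For compound 4 the estimated value is 38 nM, with an expected range of 19 nM to 76 nM.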

Compound 4, half-maximal inhibitory concentration in the HCT-116 assay: 45 nM
The estimate for compound 4 lay 1.2-fold (0.07 log units) below the measured number, and the stated range covers the measured number.
By their numbers in the HCT-116 assay, from the lowest: compounds 2, 1, 3 and 4 (each within the scatter of the next).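

The hydroxy-bearing chain can now be read directly: in the HCT-116 assay, compound 4 gives 45 nM and isopropyl in place of methyl on a saturated chain carbon bound to a carbonyl carbon and an oxygen on a saturated carbon gives a 1.1-fold higher number from compound 3 to compound 4 (0.03 log units; within the scatter), while hydroxy in place of amino gives a 1.5-fold higher number from compound 2 to compound 4 (0.18 log units; within the scatter), and 1-hydroxy-2-methylpropyl in place of 1-aminopropyl gives a 1.4-fold higher number from compound 1 to compound 4 (0.13 log units; within the scatter), so all three steps stay within the scatter. In a physicochemical assay for solubility, at pH 7.4 (on this read-out lower numbers stand for lower solubility and higher numbers for higher solubility), compound 3 gives 60 ug/mL and compound 4 gives 30 ug/mL while the same isopropyl-for-methyl change gives a 2.0-fold lower number from compound 3 to compound 4 (0.30 log units; within the scatter), which also stays within the scatter. Nothing shown here offers an explanation for these results.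

From the compounds shown here alone, it remains open whether a longer chain or a phenyl ring at this position would also stay within the scatter. A methoxy group or a carboxylic acid in place of the hydroxy group is equally unsettled.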